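The source may report more compounds than this note shows. Statements on the series, on what has been measured and on what is new or still open speak of the compounds shown alone.

Compound 1 `COc1ccc(-c2ccc3c(c2)C(=O)C(=O)N3Cc2ccc(Cl)c(Cl)c2)cc1`: 430 nM
Compound 2 `COc1ccc(-c2ccc3c(c2)C(=O)C(=O)N3Cc2cccc(Cl)c2)cc1`: 200 nM

In a functional assay on K562 cells (Homo sapiens) for antiproliferative activity, read by MTT assay, with a stated time of 48 h (a higher number here means a weaker inhibitor, a lower number a stronger inhibitor), compound 2 stands lowest of the two, at 200 nM, and compound 1 gives 430 nM. Compound 3 `COc1ccc(-c2ccc3c(c2)C(=O)C(=O)N3Cc2ccccc2Cl)cc1` carries 2-chlorophenyl in place of 3-chlorophenyl on a saturated chain carbon bound to an amide-type nitrogen in a ring. Among the compounds with values here, only one measured step bears on this, a 2.2-fold lower number from compound 1 to compound 2 (0.33 log units; beyond the scatter), a modest change that puts hydrogen in place of chloro. That step does not relocate a chlorine, so it is only a loose guide. No change beyond the scatter is expected in this assay, with a slight lean towards a higher number. The expected step is a 1.3-fold higher number from compound 2 to compound 3 (0.10 log units; within the scatter). Compound 3 is estimated at 250 nM, within a range of 90 nM to 700 nM.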

Compound 3, half-maximal inhibitory concentration: 380 nM
For compound 3 the middle estimate is 1.5-fold (0.18 log units) below the measured one, and the stated range covers the measured number.
By their numbers in this assay, from the lowest: compounds 2, 3 and 1 (each within the scatter of the next, the first and the last beyond it).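

Relocating the chlorine, with 2-chlorophenyl in place of 3-chlorophenyl, gives a 1.9-fold higher number from compound 2 to compound 3 (0.28 log units; within the scatter) in this assay and so stays within the scatter, which the earlier removal of a chlorine did not show for a change of its position. Compound 3 also sits close to the dichloro compound, with a 1.1-fold lower number from compound 1 to compound 3 (0.05 log units; within the scatter) for 2-chlorophenyl in place of 3,4-dichlorophenyl. No measurement shown here offers an explanation for these numbers. Still open, from the compounds shown here alone, is how this position would respond to an amine or a carboxylic acid in place of the chlorine, or to a longer chain carrying the ring.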